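The source may hold more compounds than are shown below. What is called first, only, known or untested is meant among the compounds shown, and "the series" means these compounds.

Of the compounds shown here, two have been measured so far in a physicochemical assay for lipophilicity, read by HPLC; a lower number here means a more polar compound, a higher number a more lipophilic compound. Compound 1 `Cc1ccsc1C(=CCCN(C)C(CCN)C(=O)NCc1ccc(Cl)cc1)c1sccc1C` gives 5.85 and compound 2 `Cc1ccsc1C(=CCCN(C)C(CCO)C(=O)NCc1ccc(F)cc1F)c1sccc1C` gives 6.37, which places compound 1 lower of the two, by a gap beyond the scatter of repeat measurements. Compound 3 `Cc1ccsc1C(=CCCN(C)C(CCN)C(=O)NCc1ccccc1Cl)c1sccc1C` has the same atoms as compound 1, joined differently: 2-chlorophenyl in place of 4-chlorophenyl on a saturated chain carbon bound to an amide-type nitrogen. Put simply, 2-chlorophenyl stands in place of 4-chlorophenyl on a saturated chain carbon bound to an amide-type nitrogen. Among the measured compounds shown here, no two measured compounds differ in one place only, so the data offer no direct guide to this change. With no atoms gained or lost, only a slight drop is expected, and the estimated step of a number 0.10 log units lower from compound 1 to compound 3 (within the scatter) stays within the scatter. Starting from compound 1 at 5.85, compound 3 is expected to read 5.75, with an estimated range from 5.4 to 6.1.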

Compound 3, partition coefficient: 6.11
Estimate against measurement, compound 3: 0.36 log units below, outside the stated range (above it).
By their numbers in this assay, from the lowest: compounds 1, 3 and 2 (each within the scatter of the next, the first and the last beyond it).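

In this assay, 2-chlorophenyl in place of 4-chlorophenyl on a saturated chain carbon bound to an amide-type nitrogen gives a number 0.26 log units higher from compound 1 to compound 3 (within the scatter). Among the compounds shown here, this is the first pair in the set that differs in one place only, and it shows that, for these two chlorophenyl groups on the core of compound 1, rejoining the same atoms leaves a step too small to separate from repeat scatter. No measurement here speaks to the reason for this small step.

Compound 2 differs from compound 1 and from compound 3 in more than one place, so it cannot extend this comparison. As far as these compounds go, whether a plain phenyl or a cyclohexyl at the same place would also stay within the scatter of compound 1 remains open.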